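Amide variation in a series at the assay limit

The source may hold more compounds than are shown below. What is called first, only, known or untested is meant among the compounds shown, and "the series" means these compounds.

Compound 1 `CN(Cc1ccccc1F)C(=O)C1CCN(C(=O)c2ccc(S(C)(=O)=O)c([N+](=O)[O-])c2)CC1` gives > 60000 nM in an assay on isolated protein for inhibition of vitamin D3 receptor (Homo sapiens), read by fluorescence polarization; a higher number here means a weaker inhibitor, a lower number a stronger inhibitor.
Compound 2 `CN(CC(=O)N(Cc1ccccc1)Cc1ccccc1)C(=O)c1ccc(S(C)(=O)=O)c([N+](=O)[O-])c1` gives > 60000 nM in this assay.
Compound 3 `CS(=O)(=O)c1ccc(C(=O)NCC(=O)N2CCCCC2)cc1[N+](=O)[O-]` gives > 60000 nM in this assay.

Each of these three values is a limit of the measurement and not a number. For compound 3 this means its inhibition lies at the limit of > 60000 nM in this assay, at which 3 of the 3 values shown sit, so no measured potency is known for it, and its standing relative to compound 1 and compound 2 cannot be ordered. Going by the values given here, no pair among the measured compounds differs in a single place, so no measured step exists.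

Compound 4 `CN(Cc1ccccc1)C(=O)CNC(=O)c1ccc(S(C)(=O)=O)c([N+](=O)[O-])c1` differs from compound 3 by benzyl(methyl)amino in place of piperidin-1-yl on a carbonyl carbon. Among the compounds with values here, with no measured step to lean on and only a limit for compound 3, neither size nor direction can be read from the data. The expected step that the limit leaves unreadable from compound 3 to compound 4 is therefore none beyond the scatter, with the outcome most likely again a limit. For compound 4 the estimate in this assay is 100000 nM, with a range from 30000 nM to 400000 nM.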

Compound 4, half-maximal inhibitory concentration: > 60000 nM
Compound 4 gave a limit, no number (the forecaster's own chance of this, stated with the estimate: 85%); the middle value does not contradict the limit.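

No step can be read from compound 3 to compound 4, since the exchange of piperidin-1-yl for benzyl(methyl)amino joins two limits and no numbers: the limit of > 60000 nM in this assay, at which 4 of the 4 values shown sit.

The compounds shown leave open whether any amide variation on the shared core gives a measurable potency in this assay, and how these amides would rank against one another.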